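Hydroxy to Amino Swap on Two Biaryl Cores

The compounds below may be only part of what the source reports. "The series", "measured", "known", "first", "only" and "open" are said of these compounds alone.

In an ADME assay on HEK293 cells (Homo sapiens) for cytotoxicity, read by MTT assay, with a stated time of 3 days (on this read-out lower numbers stand for stronger inhibition and higher numbers for weaker inhibition), compound 1 `COc1ccc(-c2cccc(O)c2)c(OC)c1` gives 28 ug/mL. Compound 2 `COc1ccc(-c2cccc(N)c2)c(OC)c1` gives 29.2 ug/mL in this assay. The change between them, (amino in place of hydroxy on an aromatic carbon), produced a 1.0-fold higher number from compound 1 to compound 2 (0.02 log units; within the scatter). Compound 3 `COc1ccc(-c2ccc(O)cc2)cc1OC` reaches only the limit > 100 ug/mL in this assay, a limit rather than a number; this is the limit of > 100 ug/mL in this assay, at which 1 of the 3 values shown sits. The difference between the core of compound 3 and the core of compound 1 is not broken down here. Compound 4 `COc1ccc(-c2ccc(N)cc2)cc1OC` carries the change (amino in place of hydroxy on an aromatic carbon); the place differs, para to a large group here against meta to a large group before, so it is the same kind of change, not the same. He expects a number no higher from compound 3 to compound 4 (the limit leaves the size open), resting on the small step of a 1.0-fold higher number from compound 1 to compound 2 (0.02 log units; within the scatter) seen for compound 1. Compound 4 is therefore estimated at 100 ug/mL, between 50 ug/mL and 200 ug/mL.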

Compound 4, half-maximal inhibitory concentration: 23 ug/mL
Compound 4: middle estimate off by 4.3-fold (0.64 log units), on the high side; measured number below the stated range.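

In this assay, amino in place of hydroxy gave an at least 4.3-fold lower number from compound 3 to compound 4 (0.63 log units; beyond the scatter), so the change does not carry over from one core to the other at a fixed size: the same change on two cores in this assay, a 1.0-fold higher number (0.02 log units; within the scatter) from compound 1 to compound 2 and an at least 4.3-fold lower number (0.63 log units; beyond the scatter) from compound 3 to compound 4, at least 4.5-fold (0.65 log units) apart, beyond the scatter of two such steps. As far as these compounds go, compound 3 stands only at a limit, > 100 ug/mL, not a number, so the step has a lower bound and its full size stays open: the limit of > 100 ug/mL in this assay, at which 1 of the 4 values shown sits. These two pairs do not show whether the core or the place of the group accounts for the gap, and they give no rule for any further core.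

The compounds shown leave open how a carboxylic acid or an acetamide would read in the same place. They also leave open whether a third core would follow compound 2 or compound 4.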